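The source may report more compounds than this note shows. Statements on the series, on what has been measured and on what is new or still open speak of the compounds shown alone.

Measured compounds in an ADME assay on THP-1 cells (Homo sapiens) for cytotoxicity, read by MTT assay, with a stated time of 72 h; a lower number here means that less compound is needed, a higher number that more compound is needed for the effect:

compound 1 `Cc1cncc(-c2ccc3[nH]c(=O)nc(-c4ccccc4)c3c2)c1` gives > 50000 nM, which is a limit of the assay and not a number.
compound 2 `O=c1nc(-c2ccccc2)c2ccc(-c3cccnc3)cc2[nH]1` gives > 50000 nM, again a limit of the assay.
compound 3 `N#Cc1ccc(-c2cccc3[nH]c(=O)nc(-c4ccccc4)c23)cc1` gives > 50000 nM, again a limit of the assay.

Compound 1 therefore stands nowhere in particular on the numbers shown: in this assay it has only a limit, and the two other measured compounds have the same limit, so no ordering among the three can be read, and no step between measured compounds is available. Within the data shown here, the whole picture of the series so far is summed up by the limit of > 50000 nM in this assay, at which 3 of the 3 values shown sit.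

The unmeasured compound 4 `Cc1ccc2[nH]c(=O)nc(-c3ccccc3)c2c1` differs from compound 1 in one place: methyl in place of 5-methylpyridin-3-yl on an aromatic carbon. The change removes the six-membered aromatic ring with one hetero atom and leaves a methyl on the aromatic carbon of the shared core.

Nothing measured in the series gives a reason to expect compound 4 to be read differently, because every value shown sits at the limit of > 50000 nM in this assay, at which 3 of the 3 values shown sit. The expected step from compound 1 to compound 4, a step that the limit leaves unreadable from compound 1 to compound 4, is therefore none beyond the scatter, and a limit rather than a number is the most likely read-out. For compound 4 the estimate in this assay is 60000 nM, with a range from 25000 nM to 200000 nM.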

Compound 4, half-maximal effective concentration: > 50000 nM
Compound 4: a limit, no number; the forecaster's own chance of this, stated with the estimate: 80%; the middle value does not contradict the limit.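

In this assay compound 4 gives > 50000 nM, a limit of the assay and not a number. No step can be read between compound 1 and compound 4, as both sit at the same limit: the limit of > 50000 nM in this assay, at which 4 of the 4 values shown sit.

The compounds shown leave open whether methyl in place of 5-methylpyridin-3-yl changes the read-out in this assay at all.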